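A few compounds are considered here, and "the series" means these few. Any claim that something is new, unique, unknown or untested is made for them only; others in the source may bear on it.

Among the compounds with values here, compound 2 `N#CCCN1N=C(c2ccc(OCc3ccccc3)cc2)OCC1=O` holds the lowest number of the two measured so far: in an assay for inhibition of Amine oxidase [flavin-containing] B (Rattus norvegicus) (on this read-out lower numbers stand for stronger inhibition and higher numbers for weaker inhibition), compound 2 gives 18 nM. Compound 1 `N#CCCn1nc(-c2ccc(OCc3ccc(Cl)cc3)cc2)oc1=S`, which differs from it in more than one place, gives in this assay 690 nM; the two values lie well apart. Compound 3 `COc1cccc(COc2ccc(C3=NN(CCC#N)C(=O)CO3)cc2)c1` differs from compound 2 by a single change, (methoxy in place of hydrogen on an aromatic carbon). Within the data shown here, since no single-point step is measured, the expectation rests on the change alone; a step from compound 2 to compound 3 of about a 1.4-fold higher number from compound 2 to compound 3 (0.14 log units; within the scatter) is expected, within the scatter. For compound 3 the estimate in this assay is 25 nM, ranging from 8 nM to 80 nM.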

Compound 3, half-maximal inhibitory concentration: 68 nM
For compound 3 the middle estimate is 2.7-fold (0.43 log units) below the measured one, within the range that was stated.
By their numbers in this assay, from the lowest: compound 2; then compound 3; then compound 1.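

In this assay, within the data shown here, the change from benzyl to 3-methoxybenzyl gives a 3.8-fold higher number from compound 2 to compound 3 (0.58 log units; beyond the scatter), the first single-change step. A methoxy on this aromatic carbon, meta to a large group, therefore weakens inhibition modestly while leaving it measurable. Nothing measured here accounts for the step.

On these data alone, whether the loss is specific to methoxy or would follow any group at this carbon remains open. A hydroxyl, a methyl or an amine at the same place would help separate these two readings.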